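Lengthening an Alkyl Chain in a Weakly Inhibiting Series

The compounds below may be only part of what the source reports. "The series", "measured", "known", "first", "only" and "open" are said of these compounds alone.

Measured compounds:
Compound 1 `CC(C)=NNc1nc(-c2cccc([N+](=O)[O-])c2)cs1`: 1160000 nM
Compound 2 `C/C(CC(C)C)=N/Nc1nc(-c2cccc([N+](=O)[O-])c2)cs1`: 1350000 nM
Compound 3 `CCCC/C(C)=N\Nc1nc(-c2cccc([N+](=O)[O-])c2)cs1`: 1180000 nM

These three compounds share one core and differ only in what sits on a saturated chain carbon bound to a carbon with a double bond to nitrogen. In a functional assay, with a stated time of 30 min (a lower number here means a stronger inhibitor, a higher number a weaker inhibitor), compound 1 gives 1160000 nM, compound 2 gives 1350000 nM, and compound 3 gives 1180000 nM. Compound 3 stands among numbers that the assay cannot tell apart: a 1.0-fold higher number from compound 1 to compound 3 (0.01 log units; within the scatter), a 1.1-fold lower number from compound 2 to compound 3 (0.06 log units; within the scatter), and likewise a 1.2-fold higher number from compound 1 to compound 2 (0.07 log units; within the scatter). In plain terms, putting a propyl or an isopropyl group where a hydrogen was, or swapping one for the other, left the read-out where it was.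

Compound 4 `CCCCCC/C(C)=N\Nc1nc(-c2cccc([N+](=O)[O-])c2)cs1` takes the chain one stage further; the change from compound 3 is ethyl in place of hydrogen on a saturated chain carbon, four bonds along the chain from a carbon with a double bond to nitrogen. Going by the values given here, the steps that bear on this are the three chain changes above, each of them within the scatter. On that basis the added ethyl is expected to make no difference beyond the scatter, meaning a 1.0-fold higher number from compound 3 to compound 4 (0.01 log units; within the scatter). Compound 4 is therefore estimated to give 1200000 nM in this assay, with an expected range from 600000 nM to 2500000 nM.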

Compound 4, half-maximal inhibitory concentration: 1150000 nM
Compound 4: the middle estimate sits 1.0-fold (0.02 log units) above what was measured, and the stated range covers the measured number.
By their numbers in this assay, from the lowest: compounds 4, 1, 3 and 2 (each within the scatter of the next).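

In this assay, ethyl in place of hydrogen, four bonds along the chain from a carbon with a double bond to nitrogen, comes with a 1.0-fold lower number from compound 3 to compound 4 (0.01 log units; within the scatter), so taking the chain this stage further leaves the read-out where it was. The wider comparisons agree: pentyl in place of isopropyl gives a 1.2-fold lower number from compound 2 to compound 4 (0.07 log units; within the scatter), and pentyl in place of hydrogen gives a 1.0-fold lower number from compound 1 to compound 4 (0.00 log units; within the scatter), so hydrogen, propyl, isopropyl and pentyl at this position cannot be told apart by this measurement. Nothing in the information available explains this flat result.

Going by these compounds, it remains open whether any group at this position can shift the number at all, for example an amine, a carboxylic acid or a phenyl ring, none of which resembles the plain alkyl chains seen so far. Also open, on these data alone, are whether a chain longer than pentyl would behave in the same way and whether a change elsewhere on the shared core would move these weak values.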